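Phenoxy for Isopropyl: Expected Permeability of Compound 4

The source may hold more compounds than are shown below. What is called first, only, known or untested is meant among the compounds shown, and "the series" means these compounds.

Three compounds have been measured in an ADME assay on Caco-2 cells (Homo sapiens) for permeability, in the apical to basolateral direction; on this read-out lower numbers stand for lower permeability and higher numbers for higher permeability:
compound 1 `CNC(=O)c1cc(Oc2ccc3oc(Nc4cccc(C(C)C)c4)nc3c2)ccn1` gives 10 10^-6 cm/s;
compound 2 `CCc1ccc(Nc2nc3cc(Oc4ccnc(C(=O)NC)c4)ccc3o2)cc1` gives 10 10^-6 cm/s;
compound 3 `CNC(=O)c1cc(Oc2ccc3oc(Nc4ccc(C(C)C)cc4)nc3c2)ccn1` gives 10 10^-6 cm/s.

Compound 3 therefore stands level with compounds 1 and 2 at the digits shown. Every measured step is within the scatter: no change at the digits printed from compound 1 to compound 2 (within the scatter), no change at the digits printed from compound 1 to compound 3 (within the scatter) and no change at the digits printed from compound 2 to compound 3 (within the scatter). Compound 4 `CNC(=O)c1cc(Oc2ccc3oc(Nc4ccc(Oc5ccccc5)cc4)nc3c2)ccn1` differs from compound 3 by phenoxy in place of isopropyl on an aromatic carbon. For the measured compounds named here, no measured step swaps a group for a phenoxy or brings in a hydrogen-bond acceptor, so the three steps bear on this change only loosely; they show that varying the group on this ring left this assay flat. A step of at most modest size, if any, is therefore expected, leaning slightly downward. Compound 4 is expected to give 8 10^-6 cm/s, in the range 3 10^-6 cm/s to 20 10^-6 cm/s. This estimate means an expected step of a 1.3-fold lower number from compound 3 to compound 4 (0.10 log units; within the scatter).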

Compound 4, apparent permeability: 10 10^-6 cm/s
Beside the measured number, compound 4's estimate is 1.3-fold (0.10 log units) below it; the range from low to high includes it.
By their numbers in this assay, from the lowest: compounds 1, 2, 3 and 4 (each within the scatter of the next).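

In this assay, phenoxy in place of isopropyl gives no change at the digits printed from compound 3 to compound 4 (within the scatter), and phenoxy in place of ethyl gives no change at the digits printed from compound 2 to compound 4 (within the scatter). For the compounds shown here, the earlier groups at this aromatic carbon were only ethyl and isopropyl, so these steps are the first to show that adding an aromatic ring and a hydrogen-bond acceptor there still leaves this read-out flat. No measurement shown here explains this result. From the compounds shown here alone, it remains open whether an amine or a carboxylic acid at this carbon would also leave the number level.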